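The source may report more compounds than this note shows. Statements on the series, on what has been measured and on what is new or still open speak of the compounds shown alone.

Measured in (a functional assay on PANC-1 cells (Homo sapiens) for inhibition, read by MTT assay, with a stated time of 24 h; a higher number here means a weaker inhibitor, a lower number a stronger inhibitor):
- compound 1 `CC1(C)[C@H]2CC[C@]1(C)N(Cc1cn(-c3ccccc3C#N)nn1)C(=O)C2` gives 240 nM
- compound 2 `CC1(C)[C@H]2CC[C@]1(C)N(Cc1cn(-c3cccc(Cl)c3)nn1)C(=O)C2` gives 260 nM
- compound 3 `COc1ccccc1-n1cc(CN2C(=O)C[C@@H]3CC[C@@]2(C)C3(C)C)nn1` gives 120 nM

Compound 1 holds the middle of these three numbers, though it lies within the scatter of both other compounds. Compound 4 (`CC1(C)[C@H]2CC[C@]1(C)N(Cc1cn(-c3ccccc3)nn1)C(=O)C2`) is compound 1 with hydrogen in place of cyano on an aromatic carbon, ortho to a large group (hydrogen in place of cyano on an aromatic carbon). Put another way, 2-cyanophenyl becomes phenyl.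

Within the data shown here, no measured step makes exactly this change, but two come close. One puts methoxy in place of cyano on an aromatic carbon (a 2.0-fold lower number from compound 1 to compound 3 (0.30 log units; within the scatter)). The other puts 3-chlorophenyl in place of 2-cyanophenyl (a 1.1-fold higher number from compound 1 to compound 2 (0.03 log units; within the scatter)). Even the widest step among these compounds is modest (a 2.2-fold lower number from compound 2 to compound 3 (0.34 log units; beyond the scatter)). Swapping the group on this phenyl ring has therefore moved the number very little, so no step beyond the scatter is expected in (this assay). The expected change is small (a 1.2-fold lower number from compound 1 to compound 4 (0.08 log units; within the scatter)). For compound 4 the estimated value is 200 nM, with an expected range of 100 nM to 400 nM.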

Compound 4, half-maximal inhibitory concentration: 160 nM
For compound 4 the middle estimate is 1.3-fold (0.10 log units) above the measured one; the range from low to high includes it.
By their numbers in this assay, from the lowest: compounds 3, 4, 1 and 2 (each within the scatter of the next, the first and the last beyond it).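

In this assay, compound 4 has no substituent on the phenyl ring, and it stays within the scatter of all three substituted compounds (a 1.5-fold lower number from compound 1 to compound 4 (0.18 log units; within the scatter); a 1.3-fold higher number from compound 3 to compound 4 (0.12 log units; within the scatter); a 1.6-fold lower number from compound 2 to compound 4 (0.21 log units; within the scatter)). The earlier compounds only compared one substituent with another; this result adds the unsubstituted ring as a baseline and shows that, among these compounds, neither the cyano, methoxy nor chloro group is needed for a number in this range. Nothing measured here explains this tolerance.

On these data alone, whether an amine, a carboxylic acid or a longer chain on this ring would move the number beyond the scatter remains open. It is also open whether the phenyl ring itself matters, as none of these compounds carries a saturated ring such as cyclohexyl in its place.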